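Lengthening the selenocyanate chain in a cell growth assay

The source may report more compounds than this note shows. Statements on the series, on what has been measured and on what is new or still open speak of the compounds shown alone.

Measured so far:
compound 1 `COc1ccc(N(C)c2nc(C)nc3ccccc23)cc1OCCN` with 421 nM in a functional assay on LoVo cells (Homo sapiens) for inhibition, read by MTT assay, with a stated time of 48 h; on this read-out higher numbers stand for weaker inhibition and lower numbers for stronger inhibition
compound 2 `COc1ccc(N(C)c2nc(C)nc3ccccc23)cc1C(=O)OCCC[Se]C#N` with 854 nM in the same assay

On the numbers shown, compound 2 gives the highest number of the two, and the nearest is compound 1, which sits a modest distance below it. Going by the values given here, the single measured step, a 2.0-fold higher number from compound 1 to compound 2 (0.31 log units; beyond the scatter), swaps the whole side group on the aromatic carbon and so tells nothing directly about the length of the chain that carries the selenocyanate.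

Compound 3 `COc1ccc(N(C)c2nc(C)nc3ccccc23)cc1C(=O)OCCCCCC[Se]C#N` differs from compound 2 only by a group of 6 heavy atoms (4 carbon, 1 nitrogen, 1 selenium; no ring) in place of a group of 3 heavy atoms (1 carbon, 1 nitrogen, 1 selenium; no ring), on a saturated chain carbon, three bonds along the chain from an oxygen next to a carbonyl group, so the ester and the selenocyanate are kept and only the saturated chain between them grows. Among the compounds with values here, with no measured step of this kind to lean on, the change is expected to leave the number close to that of compound 2, with a step of about a 1.1-fold higher number from compound 2 to compound 3 (0.02 log units; within the scatter) that may well fall within the usual scatter in either direction. Compound 3 is therefore estimated at 900 nM, with a likely range from 400 nM to 2000 nM.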

Compound 3, half-maximal inhibitory concentration: 1050 nM
Beside the measured number, compound 3's estimate is 1.2-fold (0.07 log units) below it; the range from low to high includes it.
By their numbers in this assay, from the lowest: compound 1; then compounds 2 and 3 (each within the scatter of the next).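

In this assay, going by these compounds alone, the step from the shorter to the longer chain is a 1.2-fold higher number from compound 2 to compound 3 (0.09 log units; within the scatter), and it is the first comparison here that isolates chain length, with the ester and the selenocyanate both kept. At this place, on a saturated chain carbon, three bonds along the chain from an oxygen next to a carbonyl group, a group of 6 heavy atoms can therefore stand in for a group of 3 heavy atoms without a difference that repeated measurements could separate from scatter. No measurement of any property of these compounds is available to bear on this result.

As far as these compounds go, two chain lengths cannot establish a trend, so it remains unknown whether a longer chain than that of compound 3, or a shorter chain than that of compound 2, would give a number clearly different from these two. From the compounds shown here alone, the role of the selenocyanate also remains open, and the same ester chain ending in a nitrile, a thiocyanate or a carboxylic acid would be needed to show whether the selenium-bearing end affects the number at all.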